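Propargyl to Allyl on the Amide Nitrogen

The compounds below may be only part of what the source reports. "The series", "measured", "known", "first", "only" and "open" are said of these compounds alone.

Three compounds were examined in a toxicity assay on the whole organism (strain Icem-CET (SPF Caw)) for cytotoxicity, with Mus musculus as the target; on this read-out lower numbers stand for an effect already at smaller amounts and higher numbers for an effect only at larger amounts of compound. Compound 1 `C=CCNC(=O)/C(C)=C(/C)c1ccc(C)cc1` gives 400 mg/kg in this assay, compound 2 `C=CCNC(=O)/C(C)=C(\C)c1ccc(OC)cc1` gives 300 mg/kg, and compound 3 `C#CCNC(=O)/C(C)=C(\C)c1ccc(C)cc1` gives 150 mg/kg. Compound 3 thus sits at the low end of the three numbers: compound 2 lies within the usual scatter of it, whereas compound 1 stands apart, beyond the scatter.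

Compound 4 `C=CCNC(=O)/C(C)=C(\C)c1ccc(C)cc1` has not been measured in this assay. It differs from compound 3 in one place: vinyl in place of ethynyl on a saturated chain carbon bound to an amide-type nitrogen, so that the propargylamino of compound 3 becomes an allylamino in compound 4. Going by the values given here, no measured pair shows this change directly. The two allyl amides, compound 1 with 400 mg/kg and compound 2 with 300 mg/kg, both sit at higher numbers than the propargyl amide compound 3 with 150 mg/kg, though their cores are not identical, so any inference is loose.

On that basis compound 4 is expected to land at a higher number than compound 3, with a step of about a 2.0-fold higher number from compound 3 to compound 4 (0.30 log units; within the scatter) in this assay, near the edge of the scatter. Compound 4 is estimated at 300 mg/kg in this assay, within a range from 150 mg/kg to 600 mg/kg.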

Compound 4, dose for half-maximal effect: 150 mg/kg
Estimate against measurement, compound 4: 2.0-fold (0.30 log units) above; the measured number falls inside the stated range.
By their numbers in this assay, from the lowest: compounds 3, 4, 2 and 1 (each within the scatter of the next, the first and the last beyond it).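

In this assay, going by these compounds alone, the change from propargyl to allyl on the amide nitrogen shows no change at the digits printed from compound 3 to compound 4 (within the scatter), so at this position the two compounds cannot be told apart, which the earlier compounds, all differing from compound 3 in more than one place, could not show. Methyl in place of methoxy on an aromatic carbon gives a 2.0-fold lower number from compound 2 to compound 4 (0.30 log units; within the scatter), so this exchange does not separate the two allyl amides either. The only step here beyond the scatter is a 2.7-fold lower number from compound 1 to compound 4 (0.43 log units; beyond the scatter), and although modest, it can be tied to the configuration of the double bond alone rather than to any change of group: the fact that compounds 1 and 4 differ only in the configuration as drawn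

What the compounds shown leave open is whether the amide nitrogen tolerates groups further from allyl and propargyl, such as a longer chain like butyl, a benzyl group or a chain ending in an amine, as evenly as it tolerates these two. From the compounds shown here alone, it also remains open whether the double-bond configuration matters to the same degree in the propargyl amide or with methoxy on the aromatic carbon.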